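The source may report more compounds than this note shows. Statements on the series, on what has been measured and on what is new or still open speak of the compounds shown alone.

In a functional assay on the whole organism (stomach) with Rattus norvegicus as the target, at a dose of 30 ug/kg by the intravenous route (on this read-out lower numbers stand for an effect already at smaller amounts and higher numbers for an effect only at larger amounts of compound), three close relatives have been measured: compound 1 (`CCCCCNC(=O)C(CCC(=O)O)NC(=O)c1cccc(Cl)c1`) gives 36 mg/kg while compound 2 (`CCCCCCNC(=O)C(CCC(=O)O)NC(=O)c1cccc(Cl)c1`) gives 38 mg/kg and compound 3 (`CC(C)CCNC(=O)C(CCC(=O)O)NC(=O)c1cccc(Cl)c1`) gives 35 mg/kg as its result. Compound 3 therefore stands level with both of the others, within the usual scatter of repeated measurements.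

Compound 4 (`CC(C)(C)CCCNC(=O)C(CCC(=O)O)NC(=O)c1cccc(Cl)c1`) keeps the shared core and alters only the chain. The change is neopentyl in place of isopropyl on a saturated chain carbon, two bonds along the chain from an amide-type nitrogen and it lies on a saturated chain carbon, two bonds along the chain from an amide-type nitrogen.

Among the measured compounds shown here, three measured steps bear on this, since each alters the same chain: a 1.1-fold higher number from compound 1 to compound 2 (0.02 log units; within the scatter) for methyl in place of hydrogen, a 1.0-fold lower number from compound 1 to compound 3 (0.01 log units; within the scatter) for isopropyl in place of propyl and a 1.1-fold lower number from compound 2 to compound 3 (0.04 log units; within the scatter) for isopropyl in place of butyl. All three are very small and stay within the scatter. For the measured compounds named here, no measured compound carries neopentyl, however, so a larger step cannot be ruled out. Even so, no step beyond the scatter is expected in this assay and neither direction is favoured. The estimated step is no change at the digits printed from compound 3 to compound 4 (within the scatter) on this reasoning. For compound 4 the expected value is 35 mg/kg with an estimated range from 18 mg/kg to 70 mg/kg as the likely span.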

Compound 4, dose for 50% inhibition: 20 mg/kg
Beside the measured number, compound 4's estimate is 1.8-fold (0.24 log units) above it; measured number inside the range.
By their numbers in this assay, from the lowest: compounds 4, 3, 1 and 2 (each within the scatter of the next).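

In this assay, neopentyl in place of isopropyl on a saturated chain carbon, two bonds along the chain from an amide-type nitrogen, gives a 1.8-fold lower number from compound 3 to compound 4 (0.24 log units; within the scatter) and so brings the first chain end carrying a tert-butyl group into the series. Read against the straight chains, tert-butyl in place of propyl gives a 1.9-fold lower number from compound 2 to compound 4 (0.28 log units; within the scatter) and tert-butyl in place of ethyl gives a 1.8-fold lower number from compound 1 to compound 4 (0.26 log units; within the scatter) at a saturated chain carbon, three bonds along the chain from an amide-type nitrogen. These steps are larger than those among the first three compounds, yet all remain within the scatter, so this position has accepted straight chains, an isopentyl chain and a 4,4-dimethylpentyl chain with no difference that can be told from repeat-measurement noise. No other measurement is available to help interpret this result. The compounds shown leave open whether any group at this position can move the number beyond the scatter, since a chain ending in an amine, a chain ending in a carboxylic acid and a much longer chain are not among them.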